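Removing the amino group from the core of compound 2

This account rests on a few compounds, and the source may have more. Where it says the series, first, only, none or still open, it means among the compounds named here.

Working notes on a small set of aminothiophene ketones. Compound 1 `CC(=O)c1sc(NC(C)C)c(C#N)c1N` carries a methyl on the carbonyl carbon. In an assay for inhibition of Maternal embryonic leucine zipper kinase (Homo sapiens), read by ADP-Glo, with a stated time of 0.5 h (a lower number here means a stronger inhibitor, a higher number a weaker inhibitor), compound 1 reaches only the limit > 5000 nM. Compound 2 `CC(C)Nc1sc(C(=O)c2ccc(Cl)s2)c(N)c1C#N` places a 5-chlorothiophen-2-yl on that carbon and in this assay compound 2 gives 192 nM; compound 3 `CC(C)Nc1sc(C(=O)c2cc(Cl)cs2)c(N)c1C#N` with a 4-chlorothiophen-2-yl gives 575 nM. The steps read an at least 26-fold lower number from compound 1 to compound 2 (1.41 log units; beyond the scatter) and an at least 8.6-fold lower number from compound 1 to compound 3 (0.93 log units; beyond the scatter), and between the two isomers a 3.0-fold higher number from compound 2 to compound 3 (0.48 log units; beyond the scatter). Compound 2 thus holds the lowest number of the two measured values, compound 3 next.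

Compound 4 `CC(C)Nc1sc(C(=O)c2ccc(Cl)s2)cc1C#N` is not yet measured. It differs from compound 2 in one place: hydrogen in place of amino on an aromatic carbon. Going by the values given here, none of the measured steps touches this position; all three vary only the substituent on the carbonyl carbon, so they say nothing direct about the amino group. Experience with related ring systems is not part of these data, and the direction of the step can only be guessed. The working expectation is a loss of potency, with compound 4 estimated at 1200 nM (range 250 nM to 6000 nM), that is an expected step of a 6.3-fold higher number from compound 2 to compound 4 (0.80 log units; beyond the scatter), with some chance that only a limit is returned.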

Compound 4, half-maximal inhibitory concentration: > 5000 nM
Compound 4 ended at the assay's limit (the forecaster's own chance of this, stated with the estimate: 15%); middle value at least 4.1-fold (0.61 log units) away from the limit.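

Going by these compounds alone, the amino group on this aromatic carbon of the core proves essential to the activity of compound 2 in this assay: hydrogen in its place gives an at least 26-fold higher number from compound 2 to compound 4 (1.41 log units; beyond the scatter), a large step at a position that the earlier steps, all confined to the substituent on the carbonyl carbon, did not probe. Compound 4 keeps the 5-chlorothiophen-2-yl that separated compound 2 from compound 1, so that group alone does not sustain the activity seen for compound 2 once the amino group has gone. Compound 4 sits at a limit of the assay and not at a number, so the printed step is a minimum and the full size of the loss stays unknown: the limit of > 5000 nM in this assay, at which 2 of the 4 values shown sit.

The compounds shown leave open whether a methyl, a hydroxyl, a methylamino or an acetamido group on this carbon could stand in for amino, since hydrogen is the only replacement here. They also leave open whether the same loss follows from removing the amino group when the carbonyl carbon bears the 4-chlorothiophen-2-yl of compound 3.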